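Trimming the Side Chain on a Quinone Amine

The compounds below may be only part of what the source reports. "The series", "measured", "known", "first", "only" and "open" are said of these compounds alone.

In a functional assay on MDA-MB-453 cells (Homo sapiens) for cytotoxicity, read by MTT assay, with a stated time of 72 h (on this read-out lower numbers stand for stronger inhibition and higher numbers for weaker inhibition), compound 2 `CC1=CCC[C@H]2[C@](C)(CC3=CC(=O)C=C(N[C@@H](CC(C)C)C(=O)O)C3=O)[C@@H](C)CC[C@]12C` gives 10900 nM. Among the three measured compounds it holds the second highest number: compound 1 `CC1=CCC[C@H]2[C@](C)(CC3=CC(=O)C=C(NCCC(=O)O)C3=O)[C@@H](C)CC[C@]12C` gives 3310 nM, and compound 3 `CSCC[C@H](NC1=CC(=O)C=C(C(C)(C)C)C1=O)C(=O)O`, which carries a different core, gives 151000 nM. For the measured compounds named here, the only single-site step measured is a 3.3-fold higher number from compound 1 to compound 2 (0.52 log units; beyond the scatter), so a larger branched acid on the amine nitrogen went with a higher number there.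

Compound 4 `CC1=CCC[C@H]2[C@](C)(CC3=CC(=O)C=C(N[C@@H](C)C(=O)O)C3=O)[C@@H](C)CC[C@]12C` differs from compound 2 by hydrogen in place of isopropyl on a saturated chain carbon, two bonds along the chain from an amine nitrogen and a carbonyl carbon. Going by the values given here, no measured step covers this exact change. The nearest guide is the step from compound 1 to compound 2, which also altered the acid-bearing group on that nitrogen and was modest in size. Removing the isopropyl shrinks the group toward the smaller one carried by compound 1, so a modest step toward a lower number, or none beyond the scatter, is expected. Compound 4 is therefore estimated at 5500 nM, within 2200 nM to 14000 nM. The expected step is a 2.0-fold lower number from compound 2 to compound 4 (0.30 log units; within the scatter).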

Compound 4, half-maximal inhibitory concentration: 14700 nM
Compound 4: middle estimate off by 2.7-fold (0.43 log units), on the low side; measured number above the stated range.
By their numbers in this assay, from the lowest: compound 1; then compounds 2 and 4 (each within the scatter of the next); then compound 3.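

In this assay, the read-out does not separate isopropyl from hydrogen on this saturated chain carbon, with a 1.3-fold higher number from compound 2 to compound 4 (0.13 log units; within the scatter). The step from compound 1 to compound 2 had combined the loss of the 2-carboxyethyl group with the gain of a branched side chain, and compound 4 pulls these apart: with 1-carboxyethyl in place of 2-carboxyethyl on the amine nitrogen and no isopropyl present, there is still a 4.4-fold higher number from compound 1 to compound 4 (0.65 log units; beyond the scatter). Among these three compounds, the gap therefore goes with the change from 2-carboxyethyl to a 1-carboxy group, not with the isopropyl. Nothing available explains this result. The compounds shown leave open how a longer chain between the amine nitrogen and the carboxylic acid would read, and whether an amide in place of the carboxylic acid would keep these numbers.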